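This account rests on a few compounds, and the source may have more. Where it says the series, first, only, none or still open, it means among the compounds named here.

In a functional assay on HeLa cells (Homo sapiens) for inhibition, read by CCK-8 assay, with a stated time of 48 h (a lower number here means a stronger inhibitor, a higher number a weaker inhibitor), compound 1 `O=C1CSC(N2N=C(c3ccc(Cl)cc3)CC2c2cccc3ccccc23)=N1` gives 8840 nM. Only one other compound has been measured: compound 2 `Clc1ccc(C2=NN(C3=NC(c4ccccc4)CS3)C(c3cccc4ccccc34)C2)cc1` gives 9940 nM in this assay, and the step of a 1.1-fold higher number from compound 1 to compound 2 (0.05 log units; within the scatter) lies within the scatter, so the two cannot be told apart on the numbers shown. That step concerns a group on an amine nitrogen in a ring, not the aromatic ring that carries the chloro. Compound 3 `COc1ccc(C2=NN(C3=NC(=O)CS3)C(c3cccc4ccccc34)C2)cc1` differs from compound 1 by methoxy in place of chloro on an aromatic carbon, which read one bond further out is 4-chlorophenyl to 4-methoxyphenyl. Among the compounds with values here, no measured step touches this position, so nothing in the data points to a direction in this assay; the one step available was itself within the scatter. Compound 3 is therefore expected to show a step of a 1.0-fold higher number from compound 1 to compound 3 (0.01 log units; within the scatter), not beyond the scatter. Compound 3 is estimated at 9000 nM, with a range from 3000 nM to 27000 nM.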

Compound 3, half-maximal inhibitory concentration: 2540 nM
Compound 3: the middle estimate sits 3.5-fold (0.55 log units) above what was measured, and the stated range ends above it.
By their numbers in this assay, from the lowest: compound 3; then compounds 1 and 2 (each within the scatter of the next).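

The position para to a large group on the aromatic ring responds to change in this assay: methoxy in place of chloro gives a 3.5-fold lower number from compound 1 to compound 3 (0.54 log units; beyond the scatter) and so places compound 3 lowest by number among the three compounds. Unlike the change on the amine nitrogen in a ring, which gave a 1.1-fold higher number from compound 1 to compound 2 (0.05 log units; within the scatter), this single exchange lies beyond the scatter, making the aromatic position the first site shown at which one change separates two compounds on their numbers. No measurement at hand accounts for the shift.

With only chloro and methoxy shown at this position, it remains open whether a hydroxyl, an amine or a longer alkoxy chain there would move the number further or reverse it. Going by these compounds, it also remains open whether methoxy in place of chloro would give a similar step on compound 2.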